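From Ester to Acid on a Shared Core

This account rests on a few compounds, and the source may have more. Where it says the series, first, only, none or still open, it means among the compounds named here.

Compound 1, `CCOC(=O)C(=O)CC(=O)/C=C/c1cn(Cc2ccccc2)c2ccccc12`, was tested in an assay on isolated protein for inhibition of DNA nucleotidylexotransferase (Homo sapiens), read by scintillation counting, with a stated time of 10 min; a lower number here means a stronger inhibitor, a higher number a weaker inhibitor. In this assay compound 1 gives > 40 uM, which is a limit of the assay rather than a measured number. Compound 2, `CCOC(=O)C(=O)CC(=O)/C=C/c1cn(Cc2ccc(OC)cc2)c2ccccc12`, carries a methoxy in place of hydrogen on an aromatic carbon. In this assay compound 2 gives > 40 uM, again a limit. The step from compound 1 to compound 2 is therefore a step that the two limits leave unreadable from compound 1 to compound 2; its size cannot be read, because the limit of > 40 uM in this assay, at which 2 of the 2 values shown sit, covers both compounds. Compound 3, `O=C(/C=C/c1cn(Cc2ccccc2)c2ccccc12)CC(=O)C(=O)O`, has not yet been measured. It differs from compound 1 by hydrogen in place of ethyl on an oxygen next to a carbonyl group. For the measured compounds named here, no measured step touches this kind of change, and the only measured step is unreadable, so the data give no guidance on the size or direction to expect in this assay. On that thin basis, compound 3 is expected to show 15 uM in this assay, within a range from 2 uM to 100 uM. The step implied by this estimate is expected to be an at least 2.6-fold lower number from compound 1 to compound 3 (0.42 log units; beyond the scatter), offered with wide uncertainty.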

Compound 3, concentration for 50% inhibition: 7.9 uM
Beside the measured number, compound 3's estimate is 1.9-fold (0.28 log units) above it; measured number inside the range.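

For the compounds shown here, changing ethyl to hydrogen on an oxygen next to a carbonyl group, which turns the ethoxycarbonyl into a carboxy, is the first change on the shared core with a readable effect in this assay: it gives an at least 5.0-fold lower number from compound 1 to compound 3 (0.70 log units; beyond the scatter). This step is only a minimum, and the real gap may be larger, because compound 1 gives a limit rather than a measured number: the limit of > 40 uM in this assay, at which 2 of the 3 values shown sit. The group on this oxygen therefore matters to the read-out, since compound 3, with hydrogen there, is the only compound shown to give a measured number, while the earlier methoxy step cannot be read.

From the compounds shown here alone, it remains open whether the gain needs hydrogen on this oxygen or simply the loss of ethyl, and a methyl on the same oxygen or an amide in place of the carboxy would help separate those two readings. Going by these compounds, it is also open whether the methoxy of compound 2 would shift the number on a core that carries the carboxy of compound 3.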